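Cyclohexyl for Phenyl on the Shared Core: Tolerability Expected

The compounds below may be only part of what the source reports. "The series", "measured", "known", "first", "only" and "open" are said of these compounds alone.

Compound 1, `CO[C@@H]1[C@@H](OC)[C@H](c2ccccc2)O[C@@H]2CO[C@@H](c3ccccc3)O[C@@H]12`, has no number of its own in a functional assay on HEL cells (Homo sapiens) for cytotoxicity; a lower number here means that less compound is tolerated, a higher number that more compound is tolerated: for compound 1 the result is "not determined" (no result reported). The related compound 2, `C=CC[C@@H]1O[C@@H]2CO[C@@H](c3ccccc3)O[C@H]2[C@H](OC)[C@H]1OC`, stands the same way, as in this assay compound 2 gives "not determined" (no result reported). Only compound 3, `O[C@@H]1[C@@H](O)[C@H](c2ccccc2)O[C@@H]2CO[C@@H](c3ccc(Cl)cc3)O[C@@H]12`, carries a result, and that result is a limit rather than a number: in this assay compound 3 gives >= 100 ug/mL. Thus the one value shown sits at the limit of >= 100 ug/mL in this assay, at which 1 of the 3 values shown sits, and nothing places compound 1 above or below it.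

Compound 4, `CO[C@@H]1[C@@H](OC)[C@H](c2ccccc2)O[C@@H]2CO[C@@H](C3CCCCC3)O[C@@H]12`, differs from compound 1 by cyclohexyl in place of phenyl on a saturated ring carbon. Going by the values given here, no step between measured compounds is available to set a size for this change, so in this assay no shift beyond the usual scatter is expected in either direction; the tolerated concentration of compound 4 is expected to sit where compound 3 sits, at the limit rather than at a number. For compound 4 the expected value is 100 ug/mL, within a range of 40 ug/mL to 200 ug/mL, with a good chance that only a limit is reported.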

Compound 4, minimum cytotoxic concentration: 20 ug/mL
Estimate against measurement, compound 4: 5.0-fold (0.70 log units) above; the measured number lies below the stated range.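

In this assay, going by these compounds alone, compound 4 gives 20 ug/mL, but compound 1 has no number to set against it, so no step between compound 1 and compound 4 can be read. The compounds shown leave open whether cyclohexyl in place of phenyl on the shared core changes how much compound is tolerated.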